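The source may report more compounds than this note shows. Statements on the series, on what has been measured and on what is new or still open speak of the compounds shown alone.

Compound 2 `COc1ncc(-c2ccc3c(c2)N(C2CCCCC2)C(=O)CO3)cc1NS(=O)(=O)c1ccc(F)cc1` was tested in a functional assay on A-375 cells (Homo sapiens) for antiproliferative activity, read by MTT assay, with a stated time of 72 h; a lower number here means a stronger inhibitor, a higher number a weaker inhibitor. There compound 2 reached only the assay limit, > 40000 nM. Compound 1 `COc1ncc(-c2ccc3c(c2)N(c2ccc(C)cc2)C(=O)CO3)cc1NS(=O)(=O)c1ccc(F)cc1` differs from it by 4-methylphenyl in place of cyclohexyl on an amide-type nitrogen in a ring, and in this assay compound 1 gives 12900 nM. The step is an at least 3.1-fold lower number from compound 2 to compound 1 (0.49 log units; beyond the scatter); its size can only be stated as a floor because of the limit of > 40000 nM in this assay, at which 1 of the 3 values shown sits. Compound 3 `O=C1COc2ccc(-c3cccc(NS(=O)(=O)c4ccc(F)cc4)c3)cc2N1C1CCCCC1` gives 23800 nM in this assay; the difference between its core and the core of compound 2 is not broken down here. Compound 4 `Cc1ccc(N2C(=O)COc3ccc(-c4cccc(NS(=O)(=O)c5ccc(F)cc5)c4)cc32)cc1` has not yet been measured. Relative to compound 3 it carries 4-methylphenyl in place of cyclohexyl on an amide-type nitrogen in a ring, the same change that was made from compound 2 to compound 1. For compound 4 a step of a 4.0-fold lower number from compound 3 to compound 4 (0.60 log units; beyond the scatter) is expected, resting on the earlier step of an at least 3.1-fold lower number from compound 2 to compound 1 (0.49 log units; beyond the scatter). Compound 4 is therefore estimated at 6000 nM, between 2000 nM and 20000 nM.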

Compound 4, half-maximal inhibitory concentration: 36200 nM
Compound 4: middle estimate off by 6.0-fold (0.78 log units), on the low side; the measured number lies above the stated range.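

In this assay the exchange of cyclohexyl for 4-methylphenyl gives a 1.5-fold higher number from compound 3 to compound 4 (0.18 log units; within the scatter), so on this core it brings no change beyond the scatter. The same change therefore did not carry over from one core to the other: the same change on two cores in this assay, an at least 3.1-fold lower number (0.49 log units; beyond the scatter) from compound 2 to compound 1 and a 1.5-fold higher number (0.18 log units; within the scatter) from compound 3 to compound 4, at least 4.7-fold (0.67 log units) apart, beyond the scatter of two such steps. From the compounds shown here alone, the earlier step is known only as a floor, and its full size stays unknown: the limit of > 40000 nM in this assay, at which 1 of the 4 values shown sits. With two cores, this shows that the step cannot simply be transferred within the series, but it does not show what sets the two cores apart.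

The compounds shown leave open how either core responds to other groups on the amide-type nitrogen, such as an unsubstituted phenyl, a short ethyl chain or a chain ending in an amine. They also leave open whether a third core would follow either step.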